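The source may report more compounds than this note shows. Statements on the series, on what has been measured and on what is new or still open speak of the compounds shown alone.

Values so far in an ADME assay on MT4 cells (Homo sapiens) for cytotoxicity, read by MTT assay (on this read-out higher numbers stand for lower toxicity in this test and lower numbers for higher toxicity in this test), are these
compound 1 `O=C1c2ccccc2C(=O)N1CCOC(=S)N(C(=O)c1ccccc1[N+](=O)[O-])c1ccc(Cl)cc1` gives 21000 nM
compound 2 `O=C1c2ccccc2C(=O)N1CCOC(=S)N(C(=O)c1ccc(C(F)(F)F)cc1)c1ccc(Cl)cc1` gives 10000 nM
compound 3 `O=C1c2ccccc2C(=O)N1CCOC(=S)N(C(=O)c1cc(F)cc(F)c1)c1ccc(Cl)cc1` gives 59000 nM

Of these three, compound 3 stands highest at 59000 nM on this read-out, which makes it the least toxic in this test. Compound 4 `O=C1c2ccccc2C(=O)N1CCOC(=S)N(C(=O)c1ccc([N+](=O)[O-])cc1Cl)c1ccc(Cl)cc1` has not yet been measured. It differs from compound 3 in one group, and the change is 2-chloro-4-nitrophenyl in place of 3,5-difluorophenyl on a carbonyl carbon or, in words, 2-chloro-4-nitrophenyl in place of 3,5-difluorophenyl on a carbonyl carbon.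

Three measured steps exchange a group at this same place. Arriving at the 3,5-difluorophenyl group raised the number both times, as a 2.8-fold higher number from compound 1 to compound 3 (0.45 log units; beyond the scatter) and a 5.9-fold higher number from compound 2 to compound 3 (0.77 log units; beyond the scatter) show. The step between the other two groups, a 2.1-fold lower number from compound 1 to compound 2 (0.32 log units; beyond the scatter) in size, is also modest. Among the compounds with values here, compound 1 at 21000 nM carries a 2-nitrophenyl group and is the closest guide, although no measured compound has the incoming group. Leaving the 3,5-difluorophenyl group is therefore expected to give a modest downward step in this assay that lies beyond the scatter. The estimated change is a 2.7-fold lower number from compound 3 to compound 4 (0.43 log units; beyond the scatter) in this test. Compound 4 is estimated at 22000 nM with 8000 nM to 55000 nM as the expected range.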

Compound 4, half-maximal cytotoxic concentration: 19000 nM
Compound 4: middle estimate off by 1.2-fold (0.06 log units), on the high side; low and high end bracket the measured number.
By their numbers in this assay, from the lowest: compounds 2, 4 and 1 (each within the scatter of the next, the first and the last beyond it); then compound 3.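

In this assay, a 3.1-fold lower number from compound 3 to compound 4 (0.49 log units; beyond the scatter) shows that a second group carrying a nitro substituent also gives a clearly lower number than the 3,5-difluorophenyl group, so compound 3 remains the least toxic in this test, with each of its steps to the other three compounds beyond the scatter. The new group does not separate from the other two: a 1.1-fold lower number from compound 1 to compound 4 (0.04 log units; within the scatter) and a 1.9-fold higher number from compound 2 to compound 4 (0.28 log units; within the scatter) both lie within the scatter, so compound 4 cannot be placed in order against compound 1 or compound 2, even though those two differ from each other by more than the scatter. Nothing available explains why the 3,5-difluorophenyl group stands apart at this position.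

As far as these compounds go, all four groups on this carbonyl carbon are substituted phenyl rings, so it remains open how a plain phenyl ring, a ring with a single fluorine, or a saturated cyclohexyl ring would behave here. The rest of the core is the same in all four compounds, so these numbers also leave open how changes elsewhere in the molecule would affect the result.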